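The source may report more compounds than this note shows. Statements on the series, on what has been measured and on what is new or still open speak of the compounds shown alone.

Working notes on the series.

Two compounds sharing the same core carry a measured unbound fraction so far. Compound 1 `COCCN(C)S(=O)(=O)c1ccc(C)c(C#Cc2cc(Cl)ccc2OCC(=O)O)c1` is the lower of the two: in an ADME assay on a cell-free system (plasma, Mus musculus) (a higher number here means a larger unbound share of the compound, a lower number a smaller unbound share), compound 1 gives 0.007. Compound 2 `CN(C)S(=O)(=O)c1cncc(C#Cc2cc(Cl)ccc2OCC(=O)O)c1` sits higher, and in this assay compound 2 gives 0.034, a gap that lies beyond the usual scatter of this measurement. Among the compounds with values here, no single-point step between the two measured compounds is available, so the two values are read only as they stand.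

Compound 3 `Cc1ccc(S(=O)(=O)NC(C)C)cc1C#Cc1cc(Cl)ccc1OCC(=O)O` is the next member to be measured. Relative to compound 1 the change is isopropylamino in place of (2-methoxyethyl)(methyl)amino on a sulfonyl sulfur. The (2-methoxyethyl)(methyl)amino group leaves and the isopropylamino group enters, so the substituent on the sulfonyl sulfur becomes smaller and trades its hydrogen-bond acceptor for a hydrogen-bond donor.

With no measured step of this kind in hand, the expected step of a 1.7-fold higher number from compound 1 to compound 3 (0.23 log units; within the scatter) is small, probably upward, and may not exceed the scatter. Compound 3 is estimated at 0.012, within 0.005 to 0.03, pending the actual measurement.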

Compound 3, unbound fraction: 0.01
Estimate against measurement, compound 3: 1.2-fold (0.08 log units) above; measured number inside the range.
By their numbers in this assay, from the lowest: compounds 1 and 3 (each within the scatter of the next); then compound 2.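

Within the data shown here, this is the first step that changes one place only: on the sulfonyl sulfur of the core of compound 1, isopropylamino in place of (2-methoxyethyl)(methyl)amino gives a 1.4-fold higher number from compound 1 to compound 3 (0.15 log units; within the scatter) in this assay. For this one pair, then, replacing a substituent that has a hydrogen-bond acceptor with a smaller one that has a hydrogen-bond donor does not move the unbound fraction beyond the scatter, and the two compounds read as equal in this assay. Nothing measured on these groups accounts for the result, and the step is recorded without an explanation.

Going by these compounds, whether a morpholine ring or an unsubstituted amino group on the sulfonyl sulfur would give a step beyond the scatter remains open, as one pair does not describe the position as a whole. Compound 2 differs from compound 1 and compound 3 in more than one place, and the compounds shown offer no single-place step that would assign its separation from them to any one part of the structure.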